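Exchanging the Sulfonyl Substituent: What Compound 4 May Show

The compounds below may be only part of what the source reports. "The series", "measured", "known", "first", "only" and "open" are said of these compounds alone.

Three measured compounds share one core. Compound 1 `O=S(=O)(c1ccccc1)c1ccc(CNS(=O)(=O)N2Cc3ccncc3C2)cc1` carries a sulfonamide linker rather than a urea, and in an assay on isolated protein for inhibition of Nicotinamide phosphoribosyltransferase (Homo sapiens), read by mass spectrometry, with stated times of 15 min and 30 min (a higher number here means a weaker inhibitor, a lower number a stronger inhibitor), compound 1 gives only a limit, > 2000 nM. Compound 2 `CCCn1cc(S(=O)(=O)c2ccc(CNC(=O)N3Cc4ccncc4C3)cc2)cn1` gives 17 nM in this assay. Compound 3 `CC(C)n1cc(S(=O)(=O)c2ccc(CNC(=O)N3Cc4ccncc4C3)cc2)cn1` gives 20 nM, sitting alongside compound 2, since the step of a 1.2-fold higher number from compound 2 to compound 3 (0.07 log units; within the scatter) stays within the scatter. The value of compound 1 is the limit (the limit of > 2000 nM in this assay, at which 1 of the 3 values shown sits). Compound 4 `CCC(=O)N1CCC(S(=O)(=O)c2ccc(CNC(=O)N3Cc4ccncc4C3)cc2)CC1` differs from compound 3 by 1-propanoylpiperidin-4-yl in place of 1-isopropyl-1H-pyrazol-4-yl on a sulfonyl sulfur. Among the measured compounds shown here, the single measured step between numbers concerned only the group on the aromatic nitrogen of the same ring and was within the scatter; no measured step covers replacing the whole ring. A modest weakening is therefore expected, a 2.3-fold higher number from compound 3 to compound 4 (0.35 log units; beyond the scatter). Compound 4 is estimated at 45 nM, in a range from 10 nM to 200 nM.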

Compound 4, half-maximal inhibitory concentration: 27 nM
The estimate for compound 4 lay 1.7-fold (0.22 log units) above the measured number; measured number inside the range.
By their numbers in this assay, from the lowest: compounds 2, 3 and 4 (each within the scatter of the next). At a limit, above all of these: compound 1.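

In this assay, the sulfonyl sulfur accepts more than a change of side chain: the whole 1-isopropyl-1H-pyrazol-4-yl ring gives way to 1-propanoylpiperidin-4-yl with a 1.4-fold higher number from compound 3 to compound 4 (0.13 log units; within the scatter), and the propyl partner gives a 1.6-fold higher number from compound 2 to compound 4 (0.20 log units; within the scatter). So among these compounds, an aromatic ring on the sulfonyl sulfur is not needed for a number in this range. Nothing shown explains this tolerance. Still open, as far as these compounds go, is whether the piperidine ring holds up with a free amine in place of the propanoyl group, or with a longer acyl chain. A carboxylic acid on that ring is equally untested here.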